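This account rests on a few compounds, and the source may have more. Where it says the series, first, only, none or still open, it means among the compounds named here.

Working notes on the series, read in a functional assay on A549 cells (Homo sapiens) for antiproliferative activity, read by MTT assay, with a stated time of 72 h; a lower number here means a stronger inhibitor, a higher number a weaker inhibitor. Compound 3 `COc1cc(-n2cnc3ccc(-c4ccc(C(C)=O)cc4)cc32)cc(OC)c1OC` stands lowest at 2510 nM. Compound 1 `CCOc1ccc(-c2ccc3ncn(-c4cc(OC)c(OC)c(OC)c4)c3c2)cc1` gives 8550 nM. Compound 2 `COc1cc(-n2cnc3ccc(-c4ccccc4Cl)cc32)cc(OC)c1OC` reads > 10000 nM, which is a limit of the assay.

Compound 4 `COc1cc(-n2cnc3ccc(-c4ccc(C)cc4F)cc32)cc(OC)c1OC` differs from compound 3 as follows: 2-fluoro-4-methylphenyl in place of 4-acetylphenyl on an aromatic carbon. It loses the 4-acetylphenyl, and the two closest measured steps both ended on that group, a 3.4-fold lower number from compound 1 to compound 3 (0.53 log units; beyond the scatter) and an at least 3.9-fold lower number from compound 2 to compound 3 (0.60 log units; beyond the scatter). Each lowered the number modestly or more, so leaving it is expected to raise the number by a similar amount. The estimated step is a 2.8-fold higher number from compound 3 to compound 4 (0.45 log units; beyond the scatter) in this assay. For compound 4 the estimated value is 7000 nM, with an expected range of 3000 nM to 16000 nM.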

Compound 4, half-maximal inhibitory concentration: > 10000 nM
Compound 4: no number, only a limit; the forecaster's own chance of this, stated with the estimate: 30%; middle value at least 1.4-fold (0.15 log units) away from the limit.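

In this assay, the 4-acetylphenyl of compound 3 now stands apart from a second replacement, 2-fluoro-4-methylphenyl, with an at least 3.9-fold higher number from compound 3 to compound 4 (0.60 log units; beyond the scatter). Against the 4-ethoxyphenyl, the step reads an at least 1.1-fold higher number from compound 1 to compound 4 (0.06 log units; that floor lies within the scatter), so no order follows between those two compounds. The step from the 2-chlorophenyl compound cannot be read because compound 2 and compound 4 both sit at a limit: the limit of > 10000 nM in this assay, at which 2 of the 4 values shown sit.

Open, on these data alone, is whether the 2-fluoro or the 4-methyl goes with the loss. Also open, as far as these compounds go, is whether an amine or a carboxylic acid in place of the acetyl would keep the level of compound 3.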